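The source may hold more compounds than are shown below. What is called first, only, known or untested is meant among the compounds shown, and "the series" means these compounds.

Working notes on the series

The three measured compounds share a bicyclic core with a chloro group on it and a benzyl group bearing a chloromethyl. Compound 3 `ClCc1ccc(Cn2cnc3c(Cl)nc(Cl)nc32)cc1` and compound 2 `ClCc1cccc(Cn2cnc3c(Cl)nc(Cl)nc32)c1` are built from the same atoms joined differently; the difference between these two cores is not broken down here. In a functional assay on HOP-62 cells (Homo sapiens) for cytotoxicity, read by sulforhodamine B assay, with a stated time of 48 h (a lower number here means that less compound is tolerated, a higher number that more compound is tolerated), compound 2 gives 8310 nM, the lowest number of the three measured compounds. In this assay compound 3 gives 19500 nM, and the gap between compound 2 and compound 3 lies beyond the scatter.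

Compound 1 `Nc1nc(Cl)c2ncn(Cc3ccc(CCl)cc3)c2n1` differs from compound 3 in one place: amino in place of chloro on an aromatic carbon. In this assay compound 1 gives 91200 nM, a step of a 4.7-fold higher number from compound 3 to compound 1 (0.67 log units; beyond the scatter). Compound 1 is also the furthest of the three from compound 2.

Compound 4 `Nc1nc(Cl)c2ncn(Cc3cccc(CCl)c3)c2n1` has not yet been measured in this assay. It stands to compound 2 exactly as compound 1 stands to compound 3: amino in place of chloro on an aromatic carbon. The surroundings of the place are the same word for word in both cases, so this is the same change, now made on the core of compound 2 rather than that of compound 3. The change has been measured once among these compounds, so the expectation for compound 4 rests on that single pair: because the earlier step was a 4.7-fold higher number from compound 3 to compound 1 (0.67 log units; beyond the scatter), a step of about a 4.7-fold higher number from compound 2 to compound 4 (0.67 log units; beyond the scatter) from compound 2 to compound 4 is expected in this assay. On that basis compound 4 is estimated at 39000 nM in this assay, with a likely range from 15000 nM to 100000 nM. Within the data shown here, the measured number will show whether the single precedent carries over.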

Compound 4, concentration lethal to 50% of the cells: 58900 nM
Compound 4: middle estimate off by 1.5-fold (0.18 log units), on the low side; the measured number falls inside the stated range.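

In this assay, amino in place of chloro on an aromatic carbon gives a 7.1-fold higher number from compound 2 to compound 4 (0.85 log units; beyond the scatter), and the two measured steps can be set side by side: the same change on two cores in this assay, a 4.7-fold higher number (0.67 log units; beyond the scatter) from compound 3 to compound 1 and a 7.1-fold higher number (0.85 log units; beyond the scatter) from compound 2 to compound 4, 1.5-fold (0.18 log units) apart, within the scatter of two such steps

Across these two cores, the change therefore raises the number in the same direction and by a step of comparable size, and the small gap between the steps gives no ground for assigning the two cores different responses to it. This does not show why the number rises, and two pairs in a single cell assay do not establish that the step would hold on any core beyond these two.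

The compounds shown leave open how other groups on that aromatic carbon between two ring nitrogen atoms, such as methylamino or methoxy, would compare with chloro and amino on either core. They also leave open what part the chloromethyl group plays in these numbers, which a hydroxymethyl or plain methyl group in its place on the benzyl ring would help to settle.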